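Ester homologation on the anilino side chain of compound 3

The compounds below may be only part of what the source reports. "The series", "measured", "known", "first", "only" and "open" are said of these compounds alone.

Measured compounds:
Compound 1 `CCOC(=O)Nc1ccc(C/N=C(\S)NCc2ccc(C(C)(C)C)cc2)cc1F` gives in an assay for inhibition of transient receptor potential cation channel subfamily V member 1 (Rattus norvegicus), with a stated time of 10 min (a lower number here means a stronger inhibitor, a higher number a weaker inhibitor), a value that is only an assay limit, > 30000 nM.
Compound 2 `COCC(=O)Nc1ccc(C/N=C(\S)NCc2ccc(C(C)(C)C)cc2)cc1F` gives in this assay 10900 nM.
Compound 3 `COC(=O)CNc1ccc(C/N=C(\S)NCc2ccc(C(C)(C)C)cc2)cc1F` gives in this assay 3600 nM.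

Compound 3 holds the lowest of the two numbers in this assay; its nearest neighbour is compound 2, and the step between them is a 3.0-fold lower number from compound 2 to compound 3 (0.48 log units; beyond the scatter). The step of an at least 2.7-fold lower number from compound 1 to compound 2 (0.43 log units; beyond the scatter) and the step of an at least 8.3-fold lower number from compound 1 to compound 3 (0.92 log units; beyond the scatter) start from a limit, as stated by the limit of > 30000 nM in this assay, at which 1 of the 3 values shown sits, so only their lower bounds are known.

Compound 4 `CCOC(=O)CNc1ccc(C/N=C(\S)NCc2ccc(C(C)(C)C)cc2)cc1F` differs from compound 3 by methyl in place of hydrogen on a saturated chain carbon bound to an oxygen next to a carbonyl group. Among the measured compounds shown here, none of the measured steps alters an alkyl chain on an ester oxygen: they exchange whole groups on the aromatic nitrogen or on the carbonyl carbon. Those steps therefore bear only loosely on this change, and no direction can be read from them. Compound 4 is expected to remain close to compound 3, with an expected step of no change at the digits printed from compound 3 to compound 4 (within the scatter) that lies within the scatter. The estimate for compound 4 in this assay is 3600 nM, ranging from 1500 nM to 9000 nM.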

Compound 4, half-maximal inhibitory concentration: > 30000 nM
Compound 4: only a limit was reported; the forecaster's own chance of this, stated with the estimate: 5%; middle value at least 8.3-fold (0.92 log units) away from the limit.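

In this assay, this ester chain proves sensitive: the single methyl in place of hydrogen on a saturated chain carbon bound to an oxygen next to a carbonyl group, which turns methoxycarbonyl into ethoxycarbonyl, gives an at least 8.3-fold higher number from compound 3 to compound 4 (0.92 log units; beyond the scatter). The edge that the (methoxycarbonyl)methyl group held does not carry over to (ethoxycarbonyl)methyl, with an at least 2.7-fold higher number from compound 2 to compound 4 (0.43 log units; beyond the scatter). Compound 4 gives a value that is only an assay limit, > 30000 nM, and the step from compound 1, whose value is also a limit, cannot be read: the limit of > 30000 nM in this assay, at which 2 of the 4 values shown sit.

Going by these compounds, the true size of the rise from compound 3 to compound 4 stays open. So does whether a propyl ester or a carboxylic acid on this side chain would stay at the limit or come back towards compound 3.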